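The source may hold more compounds than are shown below. What is called first, only, known or untested is meant among the compounds shown, and "the series" means these compounds.

Compound 1 `COCCNc1nc(NC(c2ccccc2)c2ccccc2)c2c(n1)C(=O)N(C(C)C)C2`: < 1000 nM (a limit)
Compound 2 `CC(=O)N1CCN(c2nc(NC(c3ccccc3)c3ccccc3)c3c(n2)C(=O)N(C(C)C)C3)CC1`: < 1000 nM (a limit)

In a physicochemical assay for solubility, measured as thermodynamic solubility, at pH 7.4 (a lower number here means a less soluble compound, a higher number a more soluble compound), compound 2 gives only a limit, < 1000 nM. The measured data stop there: the limit of < 1000 nM in this assay, at which 2 of the 2 values shown sit. Compound 3 `CC(C)N1Cc2c(NC(c3ccccc3)c3ccccc3)nc(N3CCN(S(C)(=O)=O)CC3)nc2C1=O` differs from compound 2 by methylsulfonyl in place of acetyl on an amine nitrogen in a ring. Within the data shown here, the one measured step, a step that the two limits leave unreadable from compound 1 to compound 2, lies at a different change and has no readable size, so it offers no guide. No step beyond the scatter is therefore expected, and the estimated step is a step that the limit leaves unreadable from compound 2 to compound 3. For compound 3 the expected value in this assay is 500 nM, with an estimated range of 150 nM to 1000 nM.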

Compound 3, solubility: < 1000 nM
Compound 3 ended at the assay's limit (the forecaster's own chance of this, stated with the estimate: 85%); the middle value is on the limit's open side.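

No step can be read among compound 1, compound 2 and compound 3 in this assay, because each value is a limit: the limit of < 1000 nM in this assay, at which 3 of the 3 values shown sit.

The compounds shown leave open the actual solubility of each compound, and so whether methylsulfonyl in place of acetyl changes it at all.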